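Cyclopentyl gives way to (furan-2-yl)methyl on the double-bonded nitrogen

A few compounds are considered here, and "the series" means these few. Any claim that something is new, unique, unknown or untested is made for them only; others in the source may bear on it.

Compound 1 `CCCCC/N=C(\NC#N)Nc1cccnc1`: in a functional assay on the whole organism (blood, strain Wistar-Okamoto) with Rattus norvegicus as the target, with a stated time of 5 days (on this read-out lower numbers stand for an effect already at smaller amounts and higher numbers for an effect only at larger amounts of compound), compound 1 gives 20 mg/kg.
Compound 2 `CCCCCCC/N=C(\NC#N)Nc1cccnc1`: in this assay compound 2 reaches only > 50 mg/kg, which is a limit of the assay and not a number.
Compound 3 `N#CN/C(=N\C1CCCC1)Nc1cccnc1`: in this assay compound 3 gives 20 mg/kg.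

Compound 3 stands level with compound 1, since no change at the digits printed from compound 1 to compound 3 (within the scatter). The compound not yet measured is compound 4 `N#CN/C(=N\Cc1ccco1)Nc1cccnc1`, which differs from compound 3 in one place: (furan-2-yl)methyl in place of cyclopentyl on a double-bonded nitrogen. Among the compounds with values here, two measured steps bear on it. Exchanging pentyl for cyclopentyl, no change at the digits printed from compound 1 to compound 3 (within the scatter), left the number unchanged, while lengthening the chain, an at least 2.5-fold higher number from compound 1 to compound 2 (0.39 log units; beyond the scatter), raised it; that step rests on (the limit of > 50 mg/kg in this assay, at which 1 of the 3 values shown sits). Compound 4 exchanges one five-membered ring for another, so in this assay the expected step is no change at the digits printed from compound 3 to compound 4 (within the scatter), none beyond the scatter. Compound 4 is therefore estimated at 20 mg/kg, with a range from 10 mg/kg to 50 mg/kg.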

Compound 4, minimum effective dose: 20 mg/kg
The estimate for compound 4 equals the measured number at the digits printed; measured number inside the range.
By their numbers in this assay, from the lowest: compounds 1, 3 and 4 (each within the scatter of the next). At a limit, above all of these: compound 2.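

On the double-bonded nitrogen, (furan-2-yl)methyl, which brings an aromatic ring and a hydrogen-bond acceptor, sits at the same level in this assay as cyclopentyl (no change at the digits printed from compound 3 to compound 4 (within the scatter)) and pentyl (no change at the digits printed from compound 1 to compound 4 (within the scatter)). So far, only the longer chain of compound 2 stands apart (an at least 2.5-fold lower number from compound 2 to compound 4 (0.39 log units; beyond the scatter)). That step rests on a limit and not on a number: (the limit of > 50 mg/kg in this assay, at which 1 of the 4 values shown sits).

The compounds shown leave open whether any group on this nitrogen gives a lower number than these three. A benzyl group, or a chain ending in an amine or a carboxylic acid, could show this.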